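The source may report more compounds than this note shows. Statements on the series, on what has been measured and on what is new or still open speak of the compounds shown alone.

Measured in an ADME assay on C8166 cells (Homo sapiens) for cytotoxicity, read by colorimetric assay and MTT assay; a lower number here means that less compound is tolerated, a higher number that more compound is tolerated:
compound 1 `Cc1cc(S(N)(=O)=O)ccc1NC(=O)COc1ccc2ccccc2c1C(=O)c1ccccc1`: 33800 nM
compound 2 `Cc1cccc(C(=O)c2c(OCC(=O)Nc3ccc(S(N)(=O)=O)cc3C)ccc3ccccc23)c1`: 40400 nM
compound 3 `Cc1cc(S(N)(=O)=O)ccc1NC(=O)COc1ccc2ccccc2c1C(=O)c1cc(Cl)cc(C#N)c1`: 49400 nM

Compound 2 lies between compound 1 and compound 3, with a 1.2-fold higher number from compound 1 to compound 2 (0.08 log units; within the scatter) and a 1.2-fold higher number from compound 2 to compound 3 (0.09 log units; within the scatter); all three numbers sit within scatter of one another. Compound 4 `Cc1cccc(C(=O)c2c(OCC(=O)Nc3ccc(S(N)(=O)=O)cc3C)ccc3cc(C#N)ccc23)c1` differs from compound 2 by cyano in place of hydrogen on an aromatic carbon. Among the compounds with values here, no measured step adds a cyano to the shared core; the closest are a 1.5-fold higher number from compound 1 to compound 3 (0.16 log units; within the scatter) and a 1.2-fold higher number from compound 2 to compound 3 (0.09 log units; within the scatter), where a cyano arrives together with a chloro on the ring attached to the carbonyl, both within scatter. By that analogy no step beyond scatter is expected in this assay, perhaps a slight rise. Compound 4 is therefore estimated at 46000 nM, range 22000 nM to 95000 nM, a step of a 1.1-fold higher number from compound 2 to compound 4 (0.06 log units; within the scatter).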

Compound 4, half-maximal cytotoxic concentration: 15200 nM
Compound 4: middle estimate off by 3.0-fold (0.48 log units), on the high side, and the stated range ends above it.
By their numbers in this assay, from the lowest: compound 4; then compounds 1, 2 and 3 (each within the scatter of the next).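

In this assay, within the data shown here, cyano on an aromatic carbon of the fused system of two rings gives a 2.7-fold lower number from compound 2 to compound 4 (0.42 log units; beyond the scatter), the first step beyond the scatter. A cyano arriving with a chloro on the ring attached to the carbonyl gives only a 1.2-fold higher number from compound 2 to compound 3 (0.09 log units; within the scatter), so the same group does not shift the number at that site. No measurement on hand accounts for the difference between the two sites. Still open, as far as these compounds go, is whether the drop is specific to cyano at this carbon, or whether an amine or a carboxylic acid there would do the same.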